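Chloro substitution on the cinnamoyl phenyl of a pyranone series

A few compounds are considered here, and "the series" means these few. Any claim that something is new, unique, unknown or untested is made for them only; others in the source may bear on it.

Measured compounds:
Compound 1, `Cc1cc(O)c(C(=O)/C=C/c2ccccc2)c(=O)o1`: in a functional assay on HCT-116 cells (Homo sapiens) for cytotoxicity, read by MTT assay (a higher number here means a weaker inhibitor, a lower number a stronger inhibitor), compound 1 gives > 100000 nM, which is a limit of the assay and not a number.
Compound 2, `Cc1cc(O)c(C(=O)/C=C/c2ccccc2F)c(=O)o1`: in this assay compound 2 gives > 100000 nM, again a limit of the assay.
Compound 3, `Cc1cc(O)c(C(=O)/C=C/c2ccc[nH]2)c(=O)o1`: in this assay compound 3 gives > 100000 nM, also a limit of the assay.

Compound 1 therefore stands nowhere in particular on the numbers shown: only a limit is known for it, and the two other values are limits as well. This is summed up by the limit of > 100000 nM in this assay, at which 3 of the 3 values shown sit.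

The unmeasured compound 4, `Cc1cc(O)c(C(=O)/C=C/c2ccc(Cl)cc2)c(=O)o1`, differs from compound 1 by chloro in place of hydrogen on an aromatic carbon.

Two measured steps start from compound 1 and bear on this change. The step that the two limits leave unreadable from compound 1 to compound 2 cannot be sized, and the same holds for a step that the two limits leave unreadable from compound 1 to compound 3. Neither a fluoro on the same ring nor exchange of the ring itself produced a readable number, so no direction or size of effect can be taken from them.

Compound 4 is therefore expected to remain at the limit, with an estimate of 150000 nM and a range from 50000 nM to 500000 nM. The expected step is a step that the limit leaves unreadable from compound 1 to compound 4, that is, none that could be read beyond the scatter.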

Compound 4, half-maximal inhibitory concentration: 87400 nM
Compound 4: middle estimate off by 1.7-fold (0.23 log units), on the high side, within the range that was stated.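

In this assay, for the compounds shown here, compound 4 gives 87400 nM, the only number in this set rather than a limit, so chloro para to a large group on the six-membered aromatic ring is the one change from compound 1 here that ends inside the readable range. Chloro in place of hydrogen gives an at least 1.1-fold lower number from compound 1 to compound 4 (0.05 log units; that floor lies within the scatter), so the change cannot yet be called a real gain, and its true size stays open, since only a limit is known for compound 1. The other steps from compound 1 cannot be read, and the set as a whole stays close to the ceiling of the read-out: the limit of > 100000 nM in this assay, at which 3 of the 4 values shown sit.

As far as these compounds go, it remains open whether a bromo, a methoxy or an amine on the same ring carbon would also give a number, and whether chloro on another carbon of the ring would do so. With a single number in the set, no trend across substituents on this ring can be stated, and no size of effect can be assigned to chloro beyond the scatter.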